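One More Methoxy on Compound 3

This account rests on a few compounds, and the source may have more. Where it says the series, first, only, none or still open, it means among the compounds named here.

Compound 1 `COc1ccc(/C=C/C(=O)c2c(OC)cc(O)c(CC=C(C)C)c2O)cc1OC`: 15700 nM
Compound 2 `COc1cc(OC)c(OC)cc1/C=C/C(=O)c1c(OC)cc(O)c(CC=C(C)C)c1O`: 14400 nM
Compound 3 `COc1ccc(/C=C/C(=O)c2c(O)cc(O)cc2OC)cc1OC`: > 50000 nM (a limit)

In a functional assay on A549 cells (Homo sapiens) for inhibition, read by MTT assay, with a stated time of 72 h (a higher number here means a weaker inhibitor, a lower number a stronger inhibitor), compound 3 stands at > 50000 nM, which is a limit of the assay and not a number. Compound 4 `COc1cc(OC)c(OC)cc1/C=C/C(=O)c1c(O)cc(O)cc1OC` differs from compound 3 as follows: methoxy in place of hydrogen on an aromatic carbon. The same kind of change, methoxy in place of hydrogen on an aromatic carbon, has been measured once, as a 1.1-fold lower number from compound 1 to compound 2 (0.04 log units; within the scatter). Compound 4 also carries hydrogen in place of 3-methylbut-2-en-1-yl, the change seen in an at least 3.1-fold higher number from compound 1 to compound 3 (0.50 log units; beyond the scatter). No step beyond the scatter is therefore expected in this assay. The estimated step is a number no higher from compound 3 to compound 4 (the limit leaves the size open). Compound 4 is expected at 50000 nM, with an estimated range of 25000 nM to 100000 nM.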

Compound 4, half-maximal inhibitory concentration: 34200 nM
Estimate against measurement, compound 4: 1.5-fold (0.16 log units) above; measured number inside the range.
By their numbers in this assay, from the lowest: compounds 2 and 1 (each within the scatter of the next); then compound 4. At a limit, above all of these: compound 3.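

Compound 3 gives > 50000 nM in this assay and that is a limit, not a number. Adding the methoxy to this core gives an at least 1.4-fold lower number from compound 3 to compound 4 (0.16 log units; that floor lies within the scatter) and so turns the limit into a measured value, although the firm part of that step is small. With the methoxy in place, hydrogen instead of 3-methylbut-2-en-1-yl gives a 2.4-fold higher number from compound 2 to compound 4 (0.38 log units; beyond the scatter) and so confirms with two measured numbers the loss first seen against a limit.

On these data alone, the true size of the methoxy step on this core stays open, and with it whether the step differs between the two cores. As far as these compounds go, how an amine or a longer chain would fare at this position is also open.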